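The source may report more compounds than this note shows. Statements on the series, on what has been measured and on what is new or still open speak of the compounds shown alone.

Compound 1 `C/N=C(/S)C1=CC(C)(CF)Oc2ccc([N+](=O)[O-])cc21`: 77.1%
Compound 2 `C/N=C(/S)C1=CC(C)(C(F)(F)F)Oc2ccc([N+](=O)[O-])cc21`: 62.5%

Of the compounds shown here, two have been measured in a functional assay on the whole organism (aorta) with Rattus norvegicus as the target; a lower number here means a smaller maximal response, a higher number a larger maximal response. Compound 1 stands highest of the two numbers; the nearest, compound 2, shows a number 14.6 percentage points lower from compound 1 to compound 2 (beyond the scatter), a modest step beyond the scatter that goes with a trifluoromethyl in place of fluoromethyl on a saturated ring carbon.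

Compound 3 `CC1(CF)C=C(C(=O)NCCC#N)c2cc([N+](=O)[O-])ccc2O1` is not yet measured. Relative to compound 1 it carries a group of 7 heavy atoms (4 carbon, 2 nitrogen, 1 oxygen; no ring) in place of a group of 4 heavy atoms (2 carbon, 1 nitrogen, 1 sulfur; no ring), on a double-bonded ring carbon. Going by the values given here, no measured step touches this position: the single known step, a number 14.6 percentage points lower from compound 1 to compound 2 (beyond the scatter), concerns the fluoromethyl on a saturated ring carbon and says nothing about exchanging the group on the double-bonded ring carbon for a (2-cyanoethyl)carbamoyl. The data therefore give no anchor for the size or direction of the change, and the expectation must be wide. In this assay compound 3 is estimated to reach 60%, with a range from 30% to 90%. The step this estimate means is a number 17.1 percentage points lower from compound 1 to compound 3 (beyond the scatter), expected rather than known.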

Compound 3, intrinsic activity: the largest response reached, in percent of the reference agonist's: 71%
Compound 3: middle estimate off by 11 percentage points, on the low side, within the range that was stated.
By their numbers in this assay, from the lowest: compounds 2, 3 and 1 (each within the scatter of the next, the first and the last beyond it).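

On the double-bonded ring carbon, the exchange for (2-cyanoethyl)carbamoyl gives, in this assay, a number 6.1 percentage points lower from compound 1 to compound 3 (within the scatter). The earlier compounds had shown a change only at the saturated ring carbon, whereas this result shows that the maximal response of compound 1 can be kept, within the scatter, with a larger group that contains no sulfur and brings a carbonyl and a nitrile to this position. No evidence on the cause of this result is at hand.

The compounds shown leave open what a plain ethyl carbamoyl, a longer chain ending in a nitrile, or a carboxylic acid on this ring carbon would give in this assay. They also leave open whether the exchange of fluoromethyl for trifluoromethyl has the same effect when the (2-cyanoethyl)carbamoyl is present.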